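Swapping the Amine Terminus in a Series of Antiproliferative Stilbenes

A few compounds are considered here, and "the series" means these few. Any claim that something is new, unique, unknown or untested is made for them only; others in the source may bear on it.

Measured compounds:
Compound 1, `C=C(c1ccc2c(c1)C=CC(C)(C)O2)c1ccc(OC)cc1NC(=O)CNCC`: 1180 nM
Compound 2, `C=C(c1cc(OC)c(OC)c(OC)c1)c1ccc(OC)cc1NC(=O)CNCC`: 260 nM
Compound 3, `C=C(c1ccc2c(c1)C=CC(C)(C)O2)c1ccc(OC)cc1NC(=O)CN(C)C`: 430 nM

Three compounds were tested in a functional assay on A549 cells (Homo sapiens) for antiproliferative activity, read by MTT assay, with a stated time of 48 h; on this read-out higher numbers stand for weaker inhibition and lower numbers for stronger inhibition. Compound 1 gives 1180 nM, compound 2 gives 260 nM, and compound 3 gives 430 nM. Compounds 1 and 3 share one core, while compound 2 carries a different core; the difference between the two cores is not broken down here. Compound 2 has the lowest number of the three, but its gap to compound 3 lies within the scatter, so no order between those two can be read.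

One change appears in two pairs. From compound 1 to compound 3 it is dimethylamino in place of ethylamino on a saturated chain carbon bound to a carbonyl carbon, and it made a 2.7-fold lower number from compound 1 to compound 3 (0.44 log units; beyond the scatter) in this assay. The same change carries compound 2 to compound 4, `C=C(c1cc(OC)c(OC)c(OC)c1)c1ccc(OC)cc1NC(=O)CN(C)C`, as dimethylamino in place of ethylamino on a saturated chain carbon bound to a carbonyl carbon; the place is described in the same words in both pairs.

Compound 4 is the one not yet measured. Within the data shown here, with only one precedent, the step from compound 2 to compound 4 is expected to resemble the step seen from compound 1 to compound 3, because that step was a 2.7-fold lower number from compound 1 to compound 3 (0.44 log units; beyond the scatter), giving an expected 2.4-fold lower number from compound 2 to compound 4 (0.37 log units; beyond the scatter). Resting on compound 2 at 260 nM, compound 4 is estimated to give 110 nM in this assay, with a range expected from 40 nM to 300 nM.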

Compound 4, half-maximal inhibitory concentration: 130 nM
Compound 4: the middle estimate sits 1.2-fold (0.07 log units) below what was measured; the range from low to high includes it.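

In this assay, dimethylamino in place of ethylamino on a saturated chain carbon bound to a carbonyl carbon gives a 2.0-fold lower number from compound 2 to compound 4 (0.30 log units; within the scatter), so on this core the step taken alone does not establish a real difference. Set beside the earlier step on the core of compound 1, it gives no sign that the size of the change depends on the core: the same change on two cores in this assay, a 2.7-fold lower number (0.44 log units; beyond the scatter) from compound 1 to compound 3 and a 2.0-fold lower number (0.30 log units; within the scatter) from compound 2 to compound 4, 1.4-fold (0.14 log units) apart, within the scatter of two such steps. Among these compounds, this shows that the two steps agree in direction and cannot be told apart in size, which fits a change that carries over between these two cores, but it rests on a single pair per core, only one of those steps lies beyond the scatter, and it says nothing about why the steps agree or whether a third core would behave the same way.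

The compounds shown leave open how other amine termini, such as a primary amine, diethylamino, pyrrolidine or morpholine, would fare on either core in this read-out. They also leave open whether a longer chain carrying the dimethylamino group, or a carboxylic acid in place of the amine, would keep the activity seen here.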